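Swapping piperazine for piperidine in a weak HeLa inhibitor

The source may report more compounds than this note shows. Statements on the series, on what has been measured and on what is new or still open speak of the compounds shown alone.

Compound 1, `CC1CCN(c2ccc(Nc3ncc4c(n3)N(C3CCCC3)CC(=O)N4)cc2)CC1` — > 30000 nM
Compound 2, `CCN1C(=O)CN(C2CCCC2)c2nc(Nc3ccc(N4CCN(C)CC4)cc3)ncc21` — 28300 nM

Of the compounds shown here, two have been tested in a functional assay on HeLa cells (Homo sapiens) for inhibition, read by MTT assay, with a stated time of 48 h; a lower number here means a stronger inhibitor, a higher number a weaker inhibitor. Compound 1 gave only a limit of the assay, > 30000 nM (the limit of > 30000 nM in this assay, at which 1 of the 2 values shown sits). For the measured compounds named here, compound 2 gave 28300 nM, the only actual number in this set, and a weak one. Compound 3, `CCN1C(=O)CN(C2CCCC2)c2nc(Nc3ccc(N4CCC(C)CC4)cc3)ncc21`, has not yet been measured. It differs from compound 2 in one place: 4-methylpiperidin-1-yl in place of 4-methylpiperazin-1-yl on an aromatic carbon. Going by the values given here, no measured pair shows this exact change, so its size is unknown. Given that compound 2 sits at 28300 nM, the step of a 1.1-fold higher number from compound 2 to compound 3 (0.03 log units; within the scatter) is expected to be small and may well fall within the usual scatter. Compound 3 is therefore estimated at 30000 nM, between 10000 nM and 100000 nM.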

Compound 3, half-maximal inhibitory concentration: > 30000 nM
Compound 3 was reported as a limit (the forecaster's own chance of this, stated with the estimate: 55%); the middle value sits exactly at the limit.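

In this assay, placing 4-methylpiperidin-1-yl in place of 4-methylpiperazin-1-yl, on an aromatic carbon para to a large group, gives an at least 1.0-fold higher number from compound 2 to compound 3 (0.02 log units; that floor lies within the scatter). From the compounds shown here alone, compound 3 gives only a limit of the assay, > 30000 nM, so this swap brings no measurable gain in inhibition, while the true size of the step stays unknown. The step between compound 1 and compound 3, ethyl in place of hydrogen on the amide-type nitrogen, cannot be read, and most of the values now sit at the same limit: the limit of > 30000 nM in this assay, at which 2 of the 3 values shown sit.

Going by these compounds, it remains open whether any group at this position can bring the number clearly below that limit, such as a morpholine, an unsubstituted piperazine or a piperazine carrying a longer chain. On these data alone, the role of the ethyl group also remains open, as does whether a larger group on that nitrogen would change the result.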